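A Methyl Added to the Acyl Chain

The source may hold more compounds than are shown below. What is called first, only, known or untested is meant among the compounds shown, and "the series" means these compounds.

In a functional assay on A549 cells (Homo sapiens) for antiproliferative activity, read by MTT assay, with a stated time of 72 h (a higher number here means a weaker inhibitor, a lower number a stronger inhibitor), compound 3 `C/C=C/C(=O)Nc1cccc(Oc2nc(Nc3cccc(C#N)c3)nc3c2CSCC3)c1` gives 17200 nM. This is the same number as compound 2 `CC/C=C/C(=O)Nc1cccc(Oc2nc(Nc3cccc(OC)c3)nc3c2CSCC3)c1` at 17200 nM, while compound 1 `CC/C=C/C(=O)Nc1cccc(Oc2nc(Nc3ccn(C)n3)nc3c2CSCC3)c1` stands higher at 36800 nM. Compound 4 `CC/C=C/C(=O)Nc1cccc(Oc2nc(Nc3cccc(C#N)c3)nc3c2CSCC3)c1` has not yet been measured. It differs from compound 3 by methyl in place of hydrogen on a saturated chain carbon bound to a double-bonded chain carbon, turning prop-1-en-1-yl into but-1-en-1-yl. Among the compounds with values here, no measured step tests this change directly. The only one available, a 2.1-fold lower number from compound 1 to compound 2 (0.33 log units; beyond the scatter), is modest and concerns a different place, where 3-methoxyphenyl replaces 1-methyl-1H-pyrazol-3-yl on a nitrogen on an aromatic ring. Compounds 1 and 2 already carry the but-1-en-1-yl chain, and compound 2 at 17200 nM shows a number no different from that of compound 3, which carries the shorter chain. No change beyond the scatter is therefore expected in this assay. The expected step is a 1.0-fold higher number from compound 3 to compound 4 (0.02 log units; within the scatter). The estimate for compound 4 is 18000 nM, with an expected range from 8000 nM to 38000 nM.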

Compound 4, half-maximal inhibitory concentration: 10100 nM
For compound 4 the middle estimate is 1.8-fold (0.25 log units) above the measured one; the range from low to high includes it.
By their numbers in this assay, from the lowest: compounds 4, 2 and 3 (each within the scatter of the next); then compound 1.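

In this assay, the first direct test of methyl in place of hydrogen on a saturated chain carbon bound to a double-bonded chain carbon (a 1.7-fold lower number from compound 3 to compound 4 (0.23 log units; within the scatter)) shows that, with 3-cyanophenyl on the nitrogen, the but-1-en-1-yl and prop-1-en-1-yl chains cannot be told apart. Cyano in place of methoxy on an aromatic carbon also stays inside the scatter (a 1.7-fold lower number from compound 2 to compound 4 (0.23 log units; within the scatter)), whereas 3-cyanophenyl in place of 1-methyl-1H-pyrazol-3-yl gives a modest step beyond it (a 3.6-fold lower number from compound 1 to compound 4 (0.56 log units; beyond the scatter)). Nothing available accounts for these steps.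

As far as these compounds go, whether a longer chain or an amine on the acyl chain would move the number remains open. So does whether the methyl step reads the same with 3-methoxyphenyl or 1-methyl-1H-pyrazol-3-yl on the nitrogen.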